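Lengthening the propyl chain of compound 3 to butyl

A few compounds are considered here, and "the series" means these few. Any claim that something is new, unique, unknown or untested is made for them only; others in the source may bear on it.

Values in an ADME assay on BALB/3T3 cells (Mus musculus) for cytotoxicity, read by sulforhodamine B assay, with a stated time of 72 h; on this read-out higher numbers stand for weaker inhibition and lower numbers for stronger inhibition:
compound 1 `CC(=O)N[C@@H](CSC(=S)NCCCNC(=S)SC[C@H](NC(C)=O)C(=O)O)C(=O)O` gives 8650 nM
compound 2 `CC(=O)N[C@@H](CSC(=S)Nc1ccc(C)c(NC(=S)SC[C@H](NC(C)=O)C(=O)O)c1)C(=O)O` gives 54700 nM
compound 3 `CCCNC(=S)SC[C@H](NC(C)=O)C(=O)O` gives 224000 nM

Compound 3 (224000 nM) has the highest number of the three, so it inhibits most weakly, and its gaps to compound 2 and compound 1 both lie beyond the usual scatter. Compound 4 `CCCCNC(=S)SC[C@H](NC(C)=O)C(=O)O` differs from compound 3 by methyl in place of hydrogen on a saturated chain carbon, three bonds along the chain from an amide-type nitrogen, which is methyl in place of hydrogen on a saturated chain carbon, three bonds along the chain from an amide-type nitrogen, turning propyl to butyl. Among the compounds with values here, no measured pair shows so small a change. In this assay the expected result is a slight lean toward a lower number, with a 1.2-fold lower number from compound 3 to compound 4 (0.09 log units; within the scatter) estimated to stay within the scatter. The expected value for compound 4 is 180000 nM, with an estimated range (90000 nM to 350000 nM).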

Compound 4, half-maximal inhibitory concentration: 206000 nM
The estimate for compound 4 lay 1.1-fold (0.06 log units) below the measured number, within the range that was stated.
By their numbers in this assay, from the lowest: compound 1; then compound 2; then compounds 4 and 3 (each within the scatter of the next).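

In this assay, turning propyl to butyl gives a 1.1-fold lower number from compound 3 to compound 4 (0.04 log units; within the scatter), so methyl in place of hydrogen on a saturated chain carbon, three bonds along the chain from an amide-type nitrogen, does not separate these two compounds. Within the data shown here, no earlier pair differed in one place, so this is the first reading of a single change. Nothing at hand explains the result. On these data alone, whether a longer chain, an amine or a carboxylic acid in place of the butyl group would also stay within the scatter remains open.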